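Nitro added to a benzamide sulfonamide: cytotoxicity outlook

The source may hold more compounds than are shown below. What is called first, only, known or untested is meant among the compounds shown, and "the series" means these compounds.

The series is scored in an ADME assay on HEK293 cells (Homo sapiens) for cytotoxicity, read by MTT assay, with a stated time of 48 h; on this read-out lower numbers stand for stronger inhibition and higher numbers for weaker inhibition. Compound 1 `Cc1cc(NC(=O)c2ccc(Cl)c([N+](=O)[O-])c2)ccc1NS(=O)(=O)C(F)(F)F` is reported in this assay only as a limit, > 250000 nM. Compound 2 `CCS(=O)(=O)Nc1ccc(NC(=O)c2ccc(Cl)c([N+](=O)[O-])c2)cc1F` gives 83700 nM in this assay. Compound 3 `O=C(Nc1ccc(NS(=O)(=O)C(F)(F)F)c(F)c1)c1ccc(Cl)cc1` gives 79000 nM in this assay, the lowest of the two numbers given, though its nearest neighbour, compound 2, sits within the scatter of it, so the two cannot be ranked. One value, that of compound 1, is a limit (the limit of > 250000 nM in this assay, at which 1 of the 3 values shown sits).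

Compound 4 `O=C(Nc1ccc(NS(=O)(=O)C(F)(F)F)c(F)c1)c1ccc(Cl)c([N+](=O)[O-])c1` differs from compound 3 by nitro in place of hydrogen on an aromatic carbon. Among the measured compounds shown here, no pair that differs in one place has been measured, so the size of this step is unknown. Compounds 2 and 1, which both carry a nitro group, give a number and a limit, which leaves a wide field. The step from compound 3 to compound 4 is expected to be small, a 1.5-fold higher number from compound 3 to compound 4 (0.18 log units; within the scatter), at most a drift toward weaker cytotoxicity. Compound 4 is estimated at 120000 nM, within 50000 nM to 300000 nM, in this assay.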

Compound 4, half-maximal inhibitory concentration: 194000 nM
Beside the measured number, compound 4's estimate is 1.6-fold (0.21 log units) below it, and the stated range covers the measured number.
By their numbers in this assay, from the lowest: compounds 3 and 2 (each within the scatter of the next); then compound 4. At a limit, above all of these: compound 1.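

In this assay, nitro in place of hydrogen on an aromatic carbon, ortho to a chloro group, gives a 2.5-fold higher number from compound 3 to compound 4 (0.39 log units; beyond the scatter), a modest move toward weaker inhibition. With the nitro group kept, trifluoromethyl in place of ethyl on a sulfonyl sulfur also has a measured size: a 2.3-fold higher number from compound 2 to compound 4 (0.37 log units; beyond the scatter), so two different single changes each lead to compound 4 with a modest rise. Compound 1 is reported only as a limit, > 250000 nM. On these data alone, the step of fluoro in place of methyl on an aromatic carbon is an at least 1.2-fold lower number from compound 1 to compound 4 (0.11 log units; that floor lies within the scatter), so its full size stays unknown.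

Nothing measured here accounts for either step. As far as these compounds go, whether an amine or a carboxylic acid on that same aromatic carbon would move the number in the same direction stays open.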